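A few compounds are considered here, and "the series" means these few. Any claim that something is new, unique, unknown or untested is made for them only; others in the source may bear on it.

Three compounds built on a shared core, an acrylamide bearing a bromine on its terminal carbon joined through an amide to a chalcone, have been tested in a functional assay on MOLT-4 cells (Homo sapiens) for antiproliferative activity, with a stated time of 48 h; on this read-out higher numbers stand for weaker inhibition and lower numbers for stronger inhibition. Compound 1, `C=C(Br)C(=O)Nc1ccc(C(=O)/C=C/c2ccc(OC)cc2)cc1`, carries a single methoxy group on the far ring and gives 610 nM. Compound 2, `C=C(Br)C(=O)Nc1ccc(C(=O)/C=C/c2ccc(OC)cc2OC)cc1`, differs from compound 1 by methoxy in place of hydrogen on an aromatic carbon. Compound 2 gives 1500 nM, so that a 2.5-fold higher number from compound 1 to compound 2 (0.39 log units; beyond the scatter). Compound 3, `C=C(Br)C(=O)Nc1ccc(C(=O)/C=C/c2cc(OC)cc(OC)c2)cc1`, gives 1500 nM, level with compound 2 at the digits shown; the difference between the core of compound 3 and the core of compound 1 is not broken down here.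

The unmeasured compound 4, `C=C(Br)C(=O)Nc1ccc(C(=O)/C=C/c2cc(OC)c(OC)c(OC)c2)cc1`, differs from compound 3 by methoxy in place of hydrogen on an aromatic carbon. Within the data shown here, this is the same kind of change as the one from compound 1 to compound 2, but the surroundings differ: in compound 2 the new methoxy sits ortho to a large group and meta to a methoxy group, whereas in compound 4 it sits ortho to two methoxy groups and para to a large group. Because adding a methoxy group in the earlier case produced a 2.5-fold higher number from compound 1 to compound 2 (0.39 log units; beyond the scatter), a further small weakening is expected here, of about a 1.5-fold higher number from compound 3 to compound 4 (0.17 log units; within the scatter) in this assay. Compound 4 is therefore estimated at 2200 nM, most likely between 900 nM and 5000 nM.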

Compound 4, half-maximal inhibitory concentration: 280 nM
The estimate for compound 4 lay 7.9-fold (0.90 log units) above the measured number; measured number below the stated range.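

In this assay, methoxy in place of hydrogen on the far ring gives a 5.4-fold lower number from compound 3 to compound 4 (0.73 log units; beyond the scatter), so the change that weakened inhibition on the core of compound 1 strengthens it on the core of compound 3. This change therefore cannot be carried from one core to another in this series as a fixed step, and here even its direction is not kept: the same change on two cores in this assay, a 2.5-fold higher number (0.39 log units; beyond the scatter) from compound 1 to compound 2 and a 5.4-fold lower number (0.73 log units; beyond the scatter) from compound 3 to compound 4, 13-fold (1.12 log units) apart, beyond the scatter of two such steps These two pairs do not explain why the steps differ, and they give no general rule for predicting the effect of a methoxy group on other cores, showing only that the outcome differed between the two cores tested here.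

From the compounds shown here alone, it remains open whether the stronger inhibition of compound 4, at 280 nM, is specific to methoxy or would also appear with an ethoxy group, a hydroxyl group or a fluorine atom in the same place on the core of compound 3. Going by these compounds, it is also open whether that result depends on the bromine of the acrylamide, which a chlorine atom or plain hydrogen in its place on compound 4 would test.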